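This account rests on a few compounds, and the source may have more. Where it says the series, first, only, none or still open, it means among the compounds named here.

Measured compounds:
compound 1, `Nc1ccc2cccc(OCCCNC(=O)c3cccc(Cl)c3)c2n1`, 7 nM
compound 2, `Nc1ccc2cccc(O[C@H]3CCN(Cc4ccccc4)C3)c2n1`, 1690 nM

In a functional assay on IMR-32 cells with melanin-concentrating hormone receptor 1 (Homo sapiens) as the target, read by fluorescence (on this read-out higher numbers stand for weaker inhibition and lower numbers for stronger inhibition), compound 2 holds the highest of the two numbers; its nearest neighbour, compound 1, sits far lower, well beyond the scatter. Compound 3, `Nc1ccc2cccc(O[C@@H]3CCN(Cc4ccccc4)C3)c2n1`, is not yet measured. It differs from compound 2 in this way: the two compounds have the same atoms and bonds and differ only in configuration as drawn: 1 of 1 stereo elements differ; a stereocentre at a saturated ring carbon is drawn S in compound 2 and R in compound 3. Among the measured compounds shown here, no step between measured compounds shows what such a change does here. Since compound 2 gives 1690 nM while compound 1 gives 7 nM, the other configuration is expected to move toward lower numbers by a 4.2-fold lower number from compound 2 to compound 3 (0.63 log units; beyond the scatter), though uncertainly. Compound 3 is estimated at 400 nM, between 50 nM and 3000 nM.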

Compound 3, half-maximal inhibitory concentration: > 10000 nM
Compound 3 gave a limit, no number; the forecaster's own chance of this, stated with the estimate: 5%; middle value at least 25-fold (1.39 log units) from the limit.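

Compound 3 gives > 10000 nM in this assay and this is a limit of the assay, not a number. Turning the stereocentre at the saturated ring carbon from S to R yields an at least 5.9-fold higher number from compound 2 to compound 3 (0.77 log units; beyond the scatter) and so shows that this position is sensitive to configuration, which the earlier compounds could not show. The shift belongs to that stereocentre alone, as this establishes: the fact that compounds 2 and 3 differ only in the configuration as drawn.

From the compounds shown here alone, how far the R form truly lies from the S form stays open. So does whether the S preference would persist with a benzoyl group or a longer chain in place of the benzyl group.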